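This account rests on a few compounds, and the source may have more. Where it says the series, first, only, none or still open, it means among the compounds named here.

In an assay on HEK293 cells for positive allosteric modulation of metabotropic glutamate receptor 2 (Rattus norvegicus), read by thallium flux, with a stated time of 2.5 min (a lower number here means a smaller maximal response, a higher number a larger maximal response), three compounds share one core and differ only in the aryl group carried on an oxygen on a saturated carbon. Compound 1 `Cc1c(OCCCCOc2ccc(C(=O)O)cc2)ccc(C(=O)CC2CCCC2)c1O` gives 82.6%. Compound 2 `Cc1c(OCCCCOc2ccccc2C(=O)O)ccc(C(=O)CC2CCCC2)c1O` gives 98.8%. Compound 3 `COc1ccc(C(=O)O)cc1OCCCCOc1ccc(C(=O)CC2CCCC2)c(O)c1C` gives 91.8%, which places it second highest of the three numbers; its nearest neighbour is compound 2 and its furthest is compound 1, and both gaps lie within the scatter. The step of a number 16.2 percentage points higher from compound 1 to compound 2 (beyond the scatter) is the only one beyond the scatter, while a number 9.2 percentage points higher from compound 1 to compound 3 (within the scatter) and a number 7 percentage points lower from compound 2 to compound 3 (within the scatter) stay within it. Compound 4 `Cc1cc(OCCCCOc2ccc(C(=O)CC3CCCC3)c(O)c2C)ccc1C(=O)O` is not yet measured and differs from compound 3 as follows: 4-carboxy-3-methylphenyl in place of 5-carboxy-2-methoxyphenyl on an oxygen on a saturated carbon. The measured steps that bear on this change are those exchanging the carboxyphenyl group, and they ranged from within the scatter to modest. Compound 4 is therefore expected to show a step of a number 1.8 percentage points lower from compound 3 to compound 4 (within the scatter), with no direction clearly beyond the scatter. The estimate for compound 4 in this assay is 90%, within 77% to 103%.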

Compound 4, largest response reached (reported as percent of maximum), in percent of the reference or control that the assay uses: 83.6%
Estimate against measurement, compound 4: 6.4 percentage points above; measured number inside the range.
By their numbers in this assay, from the lowest: compounds 1, 4, 3 and 2 (each within the scatter of the next, the first and the last beyond it).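

In this assay, methyl in place of hydrogen on an aromatic carbon gives a number 1 percentage points higher from compound 1 to compound 4 (within the scatter) and so leaves the 4-carboxyphenyl series within the scatter. The change from 5-carboxy-2-methoxyphenyl to 4-carboxy-3-methylphenyl gives a number 8.2 percentage points lower from compound 3 to compound 4 (within the scatter) and is also within it, whereas 4-carboxy-3-methylphenyl in place of 2-carboxyphenyl gives a number 15.2 percentage points lower from compound 2 to compound 4 (beyond the scatter) and is the second step beyond the scatter, so compound 2 now stands apart from both compound 1 and compound 4, though not from compound 3. Nothing measured here bears on the reason for these differences.

Every compound shown carries a carboxylic acid on its aryl ring, so what an amide or a tetrazole would do at that place remains open. From the compounds shown here alone, the effect of a shorter or longer chain on the oxygen, and of methyl added to the 2-carboxyphenyl group, also remains open.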